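The source may report more compounds than this note shows. Statements on the series, on what has been measured and on what is new or still open speak of the compounds shown alone.

Series notes. Compound 1 `CC(=O)Nc1nc(OCc2ccc(I)cc2)c2ncn(C3O[C@H](O)[C@@H](O)[C@H]3O)c2n1` in a functional assay on M4Beu cells for cytotoxicity against M4Beu cell line (Homo sapiens), in the presence of a further agent that is not named here (a higher number here means that more compound is needed for the effect, a lower number that less compound is needed), gives 82 uM. Compound 2 `CC(=O)Nc1nc(OCc2ccc(I)cc2)c2ncn(C3CC(OC(C)=O)C(OC(C)=O)O3)c2n1` gives 200 uM. Compound 3 `CC(=O)Nc1nc(OCc2ccccc2I)c2ncn(C3O[C@H](O)[C@@H](O)[C@H]3O)c2n1` gives 400 uM, the highest number of the three; its gap to compound 2 is within the scatter, its gap to compound 1 beyond it. Within the data shown here, the only measured change on the arm bound through the oxygen on the aromatic ring is a 4.9-fold higher number from compound 1 to compound 3 (0.69 log units; beyond the scatter). Compound 4 `CC(=O)Nc1nc(OCc2ccncc2)c2ncn(C3O[C@H](O)[C@@H](O)[C@H]3O)c2n1` differs from compound 3 by pyridin-4-yl in place of 2-iodophenyl on a saturated chain carbon bound to an oxygen on an aromatic ring. Among the measured compounds shown here, no measured step removes the iodine or introduces a ring nitrogen on this arm, so the direction is open; the one step seen there was modest, and a change of similar size in either direction is expected. Compound 4 is estimated at 250 uM, with a range of 80 uM to 800 uM, an expected step of a 1.6-fold lower number from compound 3 to compound 4 (0.20 log units; within the scatter).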

Compound 4, concentration for half-maximal effect: 400 uM
Estimate against measurement, compound 4: 1.6-fold (0.20 log units) below, and the stated range covers the measured number.
By their numbers in this assay, from the lowest: compound 1; then compounds 2, 3 and 4 (each within the scatter of the next).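

On the arm bound through the oxygen on the aromatic ring, pyridin-4-yl and 2-iodophenyl read alike in this assay, with no change at the digits printed from compound 3 to compound 4 (within the scatter). Pyridin-4-yl also gives a 4.9-fold higher number from compound 1 to compound 4 (0.69 log units; beyond the scatter), so among these three arms on the shared core only 4-iodophenyl stands apart, and carrying an iodine does not by itself place a compound with compound 1, as compound 3 shows. Nothing at hand accounts for this result.

Going by these compounds, it stays open whether a plain phenyl or a 4-aminophenyl on this arm would fall with compound 1 or with compounds 3 and 4.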